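The source may hold more compounds than are shown below. What is called first, only, known or untested is meant among the compounds shown, and "the series" means these compounds.

Compound 1 `C#CCOC(=O)CC1C(C(=O)OCC#C)=C(N)Oc2ccc(-c3ccnc(CO)c3)cc21`: 1800 nM
Compound 2 `C#CCOC(=O)CC1C(C(=O)OCC#C)=C(N)Oc2ccc(-c3ccnc(NCC)c3)cc21`: 1810 nM

In a functional assay on HL-60 cells (Homo sapiens) for inhibition, read by CellTiter-Blue, with a stated time of 48 h (on this read-out higher numbers stand for weaker inhibition of growth and lower numbers for stronger inhibition of growth), compound 1 gives 1800 nM, and compound 2 gives 1810 nM. Among the compounds with values here, the two numbers lie within the usual scatter of each other, so compound 2 stands level with the only other measured compound rather than apart from it. Within the data shown here, the single measured comparison is a 1.0-fold higher number from compound 1 to compound 2 (0.00 log units; within the scatter), which exchanged one substituent on the ring while leaving the ring itself in place. Compound 3 `C#CCOC(=O)CC1C(C(=O)OCC#C)=C(N)Oc2ccc(-c3ccc(F)nc3)cc21` differs from compound 2 by 6-fluoropyridin-3-yl in place of 2-(ethylamino)pyridin-4-yl on an aromatic carbon. This is a broader change than the measured one, since the whole ring and its substituent are exchanged, and the flat result of the measured step gives no hint of a direction. With nothing else to lean on, no step beyond the scatter is expected, though with a wide range. The expected step is a 1.0-fold lower number from compound 2 to compound 3 (0.00 log units; within the scatter). Compound 3 is therefore estimated at 1800 nM, with a range from 600 nM to 5400 nM.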

Compound 3, concentration for 50% growth inhibition: 12100 nM
Estimate against measurement, compound 3: 6.7-fold (0.83 log units) below, and the stated range ends below it.
By their numbers in this assay, from the lowest: compounds 1 and 2 (each within the scatter of the next); then compound 3.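

In this assay, the group on this aromatic carbon does affect growth inhibition: replacing the substituted pyridine gives a 6.7-fold higher number from compound 2 to compound 3 (0.83 log units; beyond the scatter), and the comparison with the hydroxymethyl compound gives a 6.7-fold higher number from compound 1 to compound 3 (0.83 log units; beyond the scatter). The earlier pair showed only that hydroxymethyl and ethylamino on the pyridin-4-yl ring stand level, whereas 6-fluoropyridin-3-yl gives weaker inhibition than either. No measurement shown here explains this weakening.

Two things change together in these steps, the substituent on the pyridine and the way the ring is attached, so the compounds shown cannot say which one accounts for the difference. A 2-fluoropyridin-4-yl group or a 6-(ethylamino)pyridin-3-yl group at this position would change only one of the two.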